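A side-chain change on compound 2

The source may report more compounds than this note shows. Statements on the series, on what has been measured and on what is new or still open speak of the compounds shown alone.

Measured so far in a functional assay on HCT-116 cells (Homo sapiens) for inhibition, with a stated time of 72 h; on this read-out lower numbers stand for stronger inhibition and higher numbers for weaker inhibition:
- Compound 1 `NC1CCC(Nc2nc(NCc3ccc(-c4ccccc4)cc3)c3ncn(C4CCCC4)c3n2)CC1` gives 745 nM
- Compound 2 `NC1CCC(Nc2nc(NCc3ccc(-c4ccco4)cc3)c3ncn(C4CCCC4)c3n2)CC1` gives 129 nM

Compound 2 holds the lower of the two numbers. Among the compounds with values here, the only measured step is a 5.8-fold lower number from compound 1 to compound 2 (0.76 log units; beyond the scatter), and it concerns the furan-2-yl group, which compound 3 `CC(C)(O)CNc1nc(NCc2ccc(-c3ccco3)cc2)c2ncn(C3CCCC3)c2n1` keeps. The change here lies elsewhere: 2-hydroxy-2-methylpropyl in place of 4-aminocyclohexyl on a nitrogen on an aromatic ring. Within the data shown here, no measured step covers this place, so the earlier step offers only a rough yardstick of size. In this assay a step of similar size towards a higher number is expected, though that direction is a judgement the data cannot confirm. The estimated value for compound 3 is 600 nM, with an expected range of 150 nM to 2500 nM. This estimate amounts to a 4.7-fold higher number from compound 2 to compound 3 (0.67 log units; beyond the scatter).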

Compound 3, half-maximal inhibitory concentration: 16700 nM
Compound 3: the middle estimate sits 28-fold (1.44 log units) below what was measured; the whole stated range lies below it.
By their numbers in this assay, from the lowest: compound 2; then compound 1; then compound 3.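

Replacing 4-aminocyclohexyl by 2-hydroxy-2-methylpropyl on this nitrogen gives a 130-fold higher number from compound 2 to compound 3 (2.11 log units; beyond the scatter) in this assay, so this position moves the read-out much further than the furan-2-yl change, which gave a 5.8-fold lower number from compound 1 to compound 2 (0.76 log units; beyond the scatter) on the other side of the molecule's substituents. The two groups have equal counts of hydrogen-bond donors and acceptors, so those counts do not separate them. Nothing available accounts for the size of this step. Going by these compounds, the ring and the amine leave together in this single change, and which of them matters stays open. A 4-hydroxycyclohexyl group or an open-chain 4-aminobutyl group on this nitrogen would separate the two.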